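Replacing 4-methoxybenzyl with phenyl at the solubility limit

The compounds below may be only part of what the source reports. "The series", "measured", "known", "first", "only" and "open" are said of these compounds alone.

In a physicochemical assay for solubility, read by nephelometry (on this read-out higher numbers stand for higher solubility and lower numbers for lower solubility), compound 1 (`CC1(C)C(=O)N(c2ccc(SC(F)(F)F)cc2)C(=O)N1Cc1ccnc(N2CCCCC2)c1`) gives < 0.024 ug/mL as a limit of the assay, not a number. Compound 2 (`COc1ccc(CNc2cc(CN3C(=O)N(c4ccc(SC(F)(F)F)cc4)C(=O)C3(C)C)ccn2)cc1`) gives < 0.027 ug/mL as a limit too. Among the compounds with values here, compound 2 therefore has no numeric value, and the only other value shown is also a limit. Compound 3 (`CC1(C)C(=O)N(c2ccc(SC(F)(F)F)cc2)C(=O)N1Cc1ccnc(Nc2ccccc2)c1`) differs from compound 2 by phenyl in place of 4-methoxybenzyl on a nitrogen on an aromatic ring in one place: phenyl in place of 4-methoxybenzyl on a nitrogen on an aromatic ring. Within the data shown here, the one measured step bearing on this place is a step that the two limits leave unreadable from compound 1 to compound 2 and offers no size to carry over. No step beyond the scatter is therefore expected. The expected change is an at least 1.1-fold higher number from compound 2 to compound 3 (0.04 log units; that floor lies within the scatter) in this estimate. In this assay the estimated value for compound 3 is 0.03 ug/mL with an expected range of 0.015 ug/mL to 0.3 ug/mL overall.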

Compound 3, solubility: < 0.025 ug/mL
Compound 3: only a limit was reported; the forecaster's own chance of this, stated with the estimate: 75%; middle value at least 1.2-fold (0.07 log units) away from the limit.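

In this assay compound 3 gives < 0.025 ug/mL, a limit and not a number. Within the data shown here, compound 1 and compound 2 also stand only as limits, so no step to compound 3 can be read. On these data alone, whether compound 1, compound 2 and compound 3 truly differ in this assay remains open.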